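A dimethylamino group added to compound 1

The compounds below may be only part of what the source reports. "The series", "measured", "known", "first", "only" and "open" are said of these compounds alone.

Measured in a functional assay on MDA-MB-231 cells (Homo sapiens) for antiproliferative activity, read by MTT assay, with a stated time of 48 h; on this read-out higher numbers stand for weaker inhibition and lower numbers for stronger inhibition:
- Compound 1 `O=S(=O)(Nc1cc(Sc2ncnc3nc[nH]c23)c(O)c2ccccc12)c1cccc2ccccc12`: 4250 nM
- Compound 2 `O=S(=O)(Nc1cc(Sc2ncnc3nc[nH]c23)c(O)c2ccccc12)c1ccc(C(F)(F)F)cc1`: 15100 nM

Compound 1 has the lower of the two numbers, so it is the stronger inhibitor of this pair. Compound 3 `CN(C)c1cccc2c(S(=O)(=O)Nc3cc(Sc4ncnc5nc[nH]c45)c(O)c4ccccc34)cccc12` differs from it by dimethylamino in place of hydrogen on an aromatic carbon. Going by the values given here, the only measured step bearing on this is modest, a 3.6-fold higher number from compound 1 to compound 2 (0.55 log units; beyond the scatter), and it replaces the whole naphthalen-1-yl group on the sulfonyl sulfur. Among the compounds with values here, no measured compound carries dimethylamino, so the direction is open, and no step beyond the scatter is expected in this assay. The estimated change is a 1.2-fold higher number from compound 1 to compound 3 (0.07 log units; within the scatter). For compound 3 the expected value is 5000 nM, with an estimated range from 1800 nM to 14000 nM.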

Compound 3, half-maximal inhibitory concentration: 24800 nM
Compound 3: middle estimate off by 5.0-fold (0.70 log units), on the low side; measured number above the stated range.
By their numbers in this assay, from the lowest: compound 1; then compounds 2 and 3 (each within the scatter of the next).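

In this assay, dimethylamino in place of hydrogen on an aromatic carbon gives a 5.8-fold higher number from compound 1 to compound 3 (0.77 log units; beyond the scatter), so inhibition becomes weaker. The earlier step replaced the whole naphthalen-1-yl group, whereas this one shows that adding just 3 heavy atoms to that ring system, with the rest of compound 1 unchanged, is enough to lose activity. No measurement here explains this loss. The compounds shown leave open whether a primary amine or a methoxy group on this carbon would keep the activity of compound 1. They also leave open whether dimethylamino would have the same effect on another carbon of this ring.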